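The source may hold more compounds than are shown below. What is called first, only, known or untested is meant among the compounds shown, and "the series" means these compounds.

Measured in a functional assay on MCF7 cells (Homo sapiens) for inhibition, read by sulforhodamine B assay, with a stated time of 24 h; a higher number here means a weaker inhibitor of growth, a lower number a stronger inhibitor of growth:
- compound 1 `CCOC(=O)C1=C(C)NC(=O)NC1c1cn(-c2ccccc2)nc1-c1ccccc1`: 60800 nM
- compound 2 `CCOC(=O)C1=C(C)NC(=S)NC1c1cn(-c2ccccc2)nc1-c1ccccc1`: 42000 nM
- compound 3 `CC1=C(C(=O)Nc2ccc(C)cc2)C(c2cn(-c3ccccc3)nc2-c2ccccc2)NC(=O)N1`: 71700 nM

In this assay, compound 2 at 42000 nM stands within the scatter of both compound 1 and compound 3, so the three compounds cannot be ranked on these numbers.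

The next compound to be tested is compound 4 `CC1=C(C(=O)Nc2ccc([N+](=O)[O-])cc2)C(c2cn(-c3ccccc3)nc2-c2ccccc2)NC(=S)N1`. Its difference from compound 2 is (4-nitrophenyl)amino in place of ethoxy on a carbonyl carbon. In words, (4-nitrophenyl)amino takes the place of ethoxy on a carbonyl carbon.

For the measured compounds named here, one measured step bears on this change: a 1.2-fold higher number from compound 1 to compound 3 (0.07 log units; within the scatter). There, (4-methylphenyl)amino replaces ethoxy on a carbonyl carbon, and the step stays within the scatter. The parallel is only partial. That step was taken on the core of compound 1, not that of compound 2, and it involved (4-methylphenyl)amino, not (4-nitrophenyl)amino. Going by the values given here, no measured compound here carries the nitro group, so the uncertainty is wider than the measured step alone would suggest.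

On this evidence, no shift beyond the scatter is expected in this assay, and no direction can be favoured. The expected change is a 1.1-fold lower number from compound 2 to compound 4 (0.02 log units; within the scatter).

For compound 4 the estimated value is 40000 nM, with an expected range of 15000 nM to 90000 nM.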

Compound 4, concentration for 50% growth inhibition: 41400 nM
Compound 4: the middle estimate sits 1.0-fold (0.01 log units) below what was measured; low and high end bracket the measured number.
By their numbers in this assay, from the lowest: compounds 4, 2, 1 and 3 (each within the scatter of the next).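

In this assay, putting (4-nitrophenyl)amino in place of ethoxy on the carbonyl carbon gives a 1.0-fold lower number from compound 2 to compound 4 (0.01 log units; within the scatter). The earlier compounds showed a replacement of ethoxy at this place only on the core of compound 1 and only with (4-methylphenyl)amino; this result extends the observation to the core of compound 2 and to a group carrying nitro, so both ethoxy-to-arylamino steps shown now stay within the scatter, despite the larger group with its added aromatic ring and hydrogen-bond donor. Nothing available here explains why the number holds steady across this change.

The compounds shown leave open whether a different kind of group on this carbonyl carbon, such as a simple alkylamine, a longer alkoxy chain or a free carboxylic acid, would move the number beyond the scatter. Compound 3 and compound 4 differ in two places, so the nitro and methyl groups cannot be compared directly, and a nitro-bearing partner on the core of compound 1 would be needed to separate them.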